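From 4-(trifluoromethyl)phenyl to 2-ethoxyphenyl on an amine nitrogen

A few compounds are considered here, and "the series" means these few. Any claim that something is new, unique, unknown or untested is made for them only; others in the source may bear on it.

In a functional assay on HeLa cells (Homo sapiens) for inhibition, read by sulforhodamine B assay (a higher number here means a weaker inhibitor, a lower number a stronger inhibitor), compound 1 `COc1ccccc1NC1=CC(=O)c2nc3n(c2C1=O)[C@H]1OC[C@@H](O)[C@H]1OC3` gives 2950 nM and compound 2 `O=C1C=C(Nc2ccc(Br)cc2)C(=O)c2c1nc1n2[C@H]2OC[C@@H](O)[C@H]2OC1` gives 3830 nM. Between them lies a 1.3-fold higher number from compound 1 to compound 2 (0.11 log units; within the scatter). Compound 3 `O=C1C=C(Nc2ccc(C(F)(F)F)cc2)C(=O)c2c1nc1n2[C@H]2OC[C@@H](O)[C@H]2OC1` reads > 8000 nM, which is a limit of the assay and not a number. Compound 4 `CCOc1ccccc1NC1=CC(=O)c2nc3n(c2C1=O)[C@H]1OC[C@@H](O)[C@H]1OC3` carries 2-ethoxyphenyl in place of 4-(trifluoromethyl)phenyl on an amine nitrogen. The closest measured change, read in reverse, is an at least 2.7-fold higher number from compound 1 to compound 3 (0.43 log units; beyond the scatter), with 2-methoxyphenyl on compound 1. Also relevant is an at least 2.0-fold higher number from compound 2 to compound 3 (0.31 log units; beyond the scatter). A step of modest size or more towards a lower number is therefore expected in this assay, and the expected step is an at least 2.5-fold lower number from compound 3 to compound 4 (0.39 log units; beyond the scatter). Compound 4 is estimated at 3200 nM, with an expected range of 1400 nM to 7500 nM.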

Compound 4, half-maximal inhibitory concentration: 6040 nM
Compound 4: the middle estimate sits 1.9-fold (0.28 log units) below what was measured; low and high end bracket the measured number.
By their numbers in this assay, from the lowest: compounds 1, 2 and 4 (each within the scatter of the next, the first and the last beyond it). At a limit, above all of these: compound 3.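

In this assay, methyl in place of hydrogen on the saturated chain, which turns 2-methoxyphenyl into 2-ethoxyphenyl, is a small change confined to that chain, yet it gives a weaker inhibitor: a 2.0-fold higher number from compound 1 to compound 4 (0.31 log units; beyond the scatter). The change from 4-bromophenyl to 2-ethoxyphenyl gives a 1.6-fold higher number from compound 2 to compound 4 (0.20 log units; within the scatter). Leaving 4-(trifluoromethyl)phenyl gives an at least 1.3-fold lower number from compound 3 to compound 4 (0.12 log units; that floor lies within the scatter), only a floor, as one end of that step is a limit and not a number: the limit of > 8000 nM in this assay, at which 1 of the 4 values shown sits.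

The compounds shown leave open whether a longer chain, such as 2-propoxyphenyl, would raise the number again, or whether 2-hydroxyphenyl would lower it.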